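Lengthening a Saturated Chain: Expectation for Compound 3

The source may hold more compounds than are shown below. What is called first, only, known or untested is meant among the compounds shown, and "the series" means these compounds.

Measured so far in a functional assay on A549 cells (Homo sapiens) for cytotoxicity, read by MTT assay, with a stated time of 24 h, tested at 60 uM; a higher number here means a weaker effect of the compound at the concentration tested, a lower number a stronger effect:
Compound 1 `CCCCCCCOC(=O)CCC(=O)N1CCN(CCCOc2cc3c(Nc4ccc(F)c(Cl)c4)ncnc3cc2OC)CC1` gives 35.7%.
Compound 2 `CCCCCCCCCCCCOC(=O)CCC(=O)N1CCN(CCCOc2cc3c(Nc4ccc(F)c(Cl)c4)ncnc3cc2OC)CC1` gives 2%.

Among the measured compounds shown here, compound 2 stands lowest of the two numbers; the only measured step, a number 33.7 percentage points lower from compound 1 to compound 2 (beyond the scatter), was large and beyond the scatter. Compound 3 `CCCCCCCCCCCCCCCCOC(=O)CCC(=O)N1CCN(CCCOc2cc3c(Nc4ccc(F)c(Cl)c4)ncnc3cc2OC)CC1` takes the same kind of change one stage further: butyl in place of hydrogen on a saturated chain carbon, ten or more bonds along the chain from an oxygen next to a carbonyl group. That earlier step bears on this one, yet compound 2 already sits near the bottom of the scale in this assay, so the expected step of a number 0.5 percentage points lower from compound 2 to compound 3 (within the scatter) is none beyond the scatter. Compound 3 is therefore estimated at 1.5%, between 0% and 12%.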

Compound 3, a percentage reported as activity, at one concentration (the size of the read-out at that concentration, not a potency): 80%
The estimate for compound 3 lay 78.5 percentage points below the measured number, outside the stated range (above it).
By their numbers in this assay, from the lowest: compound 2; then compound 1; then compound 3.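

In this assay, butyl at this place gives a number 78 percentage points higher from compound 2 to compound 3 (beyond the scatter) and so reverses the earlier gain, while nonyl in place of hydrogen gives a number 44.3 percentage points higher from compound 1 to compound 3 (beyond the scatter) overall. Lengthening this chain therefore does not act in one direction: compound 2, with the middle chain length, has the strongest effect of the three, and compound 3 goes against the trend from compound 1 to compound 2. Nothing available explains this reversal. From the compounds shown here alone, the chain length at which the effect turns remains open, as does whether a longer chain, or a chain carrying an amine or a carboxylic acid, would restore it.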